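From methoxy to hydroxy in a cytotoxicity series

A few compounds are considered here, and "the series" means these few. Any claim that something is new, unique, unknown or untested is made for them only; others in the source may bear on it.

In an ADME assay on HEK293 cells (Homo sapiens) for cytotoxicity, read by resazurin assay, with a stated time of 48 h (on this read-out higher numbers stand for lower toxicity in this test and lower numbers for higher toxicity in this test), compound 1 `O=S(=O)(Nc1ccc(-c2nc3cc(NS(=O)(=O)c4ccccc4)ccc3o2)cc1)c1ccccc1` gives 25000 nM and compound 2 `O=C(Nc1ccc(Sc2nc3ccccc3s2)c(Cl)c1)c1cccc(Br)c1O` gives 68000 nM. Compound 3 `COc1c(Br)cccc1C(=O)Nc1ccc(Sc2nc3ccccc3s2)cc1` gives > 100000 nM, which is a limit of the assay and not a number. Compound 4 `O=C(Nc1ccc(Sc2nc3ccccc3s2)cc1)c1cccc(Br)c1O` differs from compound 3 by hydrogen in place of methyl on an oxygen on an aromatic ring, or methoxy to hydroxy. Within the data shown here, no measured pair shows this change. A modest move towards lower numbers in this assay is still expected because compound 2, which carries the hydroxy, gives 68000 nM. The expected step is an at least 1.4-fold lower number from compound 3 to compound 4 (0.15 log units; that floor lies within the scatter). For compound 4 the estimated value is 70000 nM, with an expected range of 30000 nM to 100000 nM.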

Compound 4, half-maximal cytotoxic concentration: 33000 nM
Estimate against measurement, compound 4: 2.1-fold (0.33 log units) above; the measured number falls inside the stated range.
By their numbers in this assay, from the lowest: compounds 1 and 4 (each within the scatter of the next); then compound 2. At a limit, above all of these: compound 3.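

In this assay, among these compounds, hydrogen in place of methyl on an oxygen on an aromatic ring gives an at least 3.0-fold lower number from compound 3 to compound 4 (0.48 log units; beyond the scatter), a reading of this change that no earlier pair offered. Compound 3 stands at a limit of the assay, so that step is only a floor: the limit of > 100000 nM in this assay, at which 1 of the 4 values shown sits. With the hydroxy kept, hydrogen in place of chloro on an aromatic carbon gives a 2.1-fold lower number from compound 2 to compound 4 (0.31 log units; beyond the scatter). From the compounds shown here alone, what an ethyl group on that oxygen, or an amine in place of the hydroxy, would give stays open. So does the size of the methoxy to hydroxy step with the chloro present.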